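Trifluoromethyl for trifluoromethoxy at the assay limit

This account rests on a few compounds, and the source may have more. Where it says the series, first, only, none or still open, it means among the compounds named here.

Compound 1 `O=C(Nc1ccc(Cl)cc1)c1cc(=O)[nH]c2cc(Br)ccc12`: > 20000 nM
Compound 2 `O=C(Nc1ccc(F)cc1)c1cc(=O)[nH]c2cc(Br)ccc12`: > 20000 nM
Compound 3 `O=C(Nc1ccc(OC(F)(F)F)cc1)c1cc(=O)[nH]c2cc(Br)ccc12`: > 20000 nM

All three compounds were tested in a functional assay on KYSE-70 cells for antiproliferative activity against KYSE-70 cell line (Homo sapiens), read by MTT assay, with a stated time of 72 h (a higher number here means a weaker inhibitor, a lower number a stronger inhibitor), and each entry is a limit of the assay, not a number. Compound 3 gives > 20000 nM, which is a limit. The whole set looks the same: the limit of > 20000 nM in this assay, at which 3 of the 3 values shown sit.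

Compound 4 `O=C(Nc1ccc(C(F)(F)F)cc1)c1cc(=O)[nH]c2cc(Br)ccc12` differs from compound 3 in one place: trifluoromethyl in place of trifluoromethoxy on an aromatic carbon. Trifluoromethyl stands in place of trifluoromethoxy on an aromatic carbon.

Three measured swaps of the group at that place bear on this change: a step that the two limits leave unreadable from compound 1 to compound 2, a step that the two limits leave unreadable from compound 1 to compound 3 and a step that the two limits leave unreadable from compound 2 to compound 3. None has a readable size, so none gives a direction, and no step beyond the scatter is expected in this assay. The estimate is therefore a number no higher from compound 3 to compound 4 (the limit leaves the size open). Compound 4 is expected near 20000 nM, within an estimated range of 9000 nM to 40000 nM.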

Compound 4, half-maximal inhibitory concentration: > 20000 nM
Compound 4 gave a limit, no number; the forecaster's own chance of this, stated with the estimate: 85%; the middle value sits exactly at the limit.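

Compound 4 also gives only a limit, so no step between it and compound 1, compound 2 or compound 3 can be read, and the whole set stays there: the limit of > 20000 nM in this assay, at which 4 of the 4 values shown sit.

The compounds shown leave open whether changing the group at this place alters activity in this assay.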